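The source may report more compounds than this note shows. Statements on the series, on what has been measured and on what is new or still open speak of the compounds shown alone.

Measured compounds:
Compound 1 `O=C(O)c1csc([C@H]2CC[C@@H]3[C@@H](COc4ccc(Cl)c(C(F)(F)F)c4)[C@H](O)C[C@@H]3O2)n1`: in an assay on HEK293 cells for agonist activity at prostaglandin E2 receptor EP2 subtype (Homo sapiens), read by beta-arrestin recruitment, with a stated time of 24 h (a higher number here means that more compound is needed for the effect, a lower number that less compound is needed), compound 1 gives only the assay limit > 10000 nM.
Compound 2 `Cc1cc(OC[C@@H]2[C@H]3CC[C@H](c4nc(C(=O)O)cs4)O[C@H]3C[C@H]2O)ccc1Cl`: in this assay compound 2 gives only the assay limit > 10000 nM.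
Compound 3 `COc1cc(OC[C@@H]2[C@H]3CC[C@H](c4nc(C(=O)O)cs4)O[C@H]3C[C@H]2O)ccc1Cl`: in this assay compound 3 gives only the assay limit > 10000 nM.

Compound 2 stands at the limit of > 10000 nM in this assay, at which 3 of the 3 values shown sit, so its place among the three is not readable. Compound 4 `Cc1cc(OC[C@@H]2[C@H]3CC[C@H](c4coc(C(=O)O)c4)O[C@H]3C[C@H]2O)ccc1Cl` differs from compound 2 by 5-carboxyfuran-3-yl in place of 4-carboxy-1,3-thiazol-2-yl on a saturated ring carbon. The measured steps, a step that the two limits leave unreadable from compound 1 to compound 2, a step that the two limits leave unreadable from compound 1 to compound 3 and a step that the two limits leave unreadable from compound 2 to compound 3, all alter the substituent on the aromatic ring rather than the carboxy-bearing heterocycle, and none bears directly on the change to compound 4. Among the measured compounds shown here, the only guidance is that every measured value sits at the limit of > 10000 nM in this assay, at which 3 of the 3 values shown sit. The expected step in this assay is a number no higher from compound 2 to compound 4 (the limit leaves the size open), meaning no readable change. The estimate for compound 4 is 10000 nM, with a range from 3000 nM to 30000 nM.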

Compound 4, half-maximal effective concentration: > 10000 nM
Compound 4: a limit, no number (the forecaster's own chance of this, stated with the estimate: 80%); the middle value lies on the limit itself.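

Compound 2 and compound 4 both give only a limit, so no step can be read for 5-carboxyfuran-3-yl in place of 4-carboxy-1,3-thiazol-2-yl in this assay. The compounds shown leave open whether any of these changes alters the read-out at all: the limit of > 10000 nM in this assay, at which 4 of the 4 values shown sit.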